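The compounds below may be only part of what the source reports. "The series", "measured", "known", "first", "only" and "open" are said of these compounds alone.

Measured compounds in an in vitro functional assay on SH-SY5Y cells for agonist activity at Neuronal acetylcholine receptor; alpha3/beta4 (Homo sapiens), read by FLIPR and calcium flux; a higher number here means a larger maximal response, a lower number a smaller maximal response:

Compound 1 `COc1cncc(C2=CC3CC(C2)CN(C)C3)c1` gives 27%.
Compound 2 `CC(C)Oc1cncc(C2=CC3CNCC(C2)C3)c1` gives 160%.
Compound 3 `COc1cncc(C2=CC3CNCC(C2)C3)c1` gives 145%.

Compound 2 stands highest of the three in this assay. Its nearest neighbour is compound 3, with a step of a number 15 percentage points lower from compound 2 to compound 3 (beyond the scatter), a modest change that comes with a methyl in place of isopropyl on an oxygen on an aromatic ring. Compound 1 lies far below it: with a value of 27% compound 1 is the weakest of the set.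

Compound 4 `CC(C)Oc1cncc(C2=CC3CC(C2)CN(C)C3)c1` is not yet measured. It differs from compound 2 in one place: methyl in place of hydrogen on an amine nitrogen in a ring. Within the data shown here, the only measured step that touches this position runs the other way, a number 118 percentage points higher from compound 1 to compound 3 (beyond the scatter), where a hydrogen replaced a methyl on the amine nitrogen in the ring and the maximal response rose by a large amount. The step from compound 2 to compound 4 reverses that change on the isopropyl-bearing core, so a drop of comparable size in this assay is expected, rather than anything small or within the scatter. The expected step for compound 4 is therefore a number 120 percentage points lower from compound 2 to compound 4 (beyond the scatter). Compound 4 is estimated at 40%, within a range of 15% to 80%.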

Compound 4, largest response reached (reported as percent of maximum), in percent of the reference or control that the assay uses: 15%
Beside the measured number, compound 4's estimate is 25 percentage points above it, within the range that was stated.
By their numbers in this assay, from the lowest: compound 4; then compound 1; then compound 3; then compound 2.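

In this assay the amine nitrogen in a ring now has a second reading: methyl in place of hydrogen gives a number 145 percentage points lower from compound 2 to compound 4 (beyond the scatter), so the large loss of maximal response holds with isopropyl on the oxygen as well as with methyl there. The direction of this change is the same on both cores, but its size depends on the group on the oxygen: the same change on two cores in this assay, a number 118 percentage points higher (beyond the scatter) from compound 1 to compound 3 and a number 145 percentage points higher (beyond the scatter) from compound 4 to compound 2, 27 percentage points apart, beyond the scatter of two such steps The change on the oxygen, by contrast, reverses with the group on the nitrogen, since with methyl on the nitrogen isopropyl in place of methyl gives a number 12 percentage points lower from compound 1 to compound 4 (beyond the scatter), while with hydrogen on the nitrogen methyl in place of isopropyl gives a number 15 percentage points lower from compound 2 to compound 3 (beyond the scatter), making isopropyl the higher of the two only on the core with hydrogen on the nitrogen: the same change on two cores in this assay, a number 15 percentage points lower (beyond the scatter) from compound 2 to compound 3 and a number 12 percentage points higher (beyond the scatter) from compound 4 to compound 1, 27 percentage points apart, beyond the scatter of two such steps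

The compounds shown carry only hydrogen or methyl on the amine nitrogen, so it remains open whether an ethyl group or a longer chain there would give a response as low as methyl does. On the oxygen only methyl and isopropyl appear, which leaves open how an ethyl or cyclopropylmethyl group would behave with either group on the nitrogen.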